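From a Methylphenyl to a Trifluoromethylphenyl Group

A few compounds are considered here, and "the series" means these few. Any claim that something is new, unique, unknown or untested is made for them only; others in the source may bear on it.

compound 1 `Cc1ccccc1N1CCN(CCCCNC(=O)c2ccc3ccccc3c2)CC1` 29.9 nM
compound 2 `O=C(NCCCCN1CCN(c2cccc(Cl)c2)CC1)c1ccc2ccccc2c1` 50.2 nM

In an assay on isolated protein for displacement of a labelled ligand from Alpha-1A adrenergic receptor (Homo sapiens) (on this read-out lower numbers stand for stronger inhibition and higher numbers for weaker inhibition), compound 1 gives the lowest of the two numbers, yet its step of a 1.7-fold higher number from compound 1 to compound 2 (0.23 log units; within the scatter) lies within the scatter, so no order between compound 1 and compound 2 can be claimed. Compound 3 `O=C(NCCCCN1CCN(c2cccc(C(F)(F)F)c2)CC1)c1ccc2ccccc2c1` differs from compound 1 by 3-(trifluoromethyl)phenyl in place of 2-methylphenyl on an amine nitrogen in a ring. Among the measured compounds shown here, the one step that bears on this change is a 1.7-fold higher number from compound 1 to compound 2 (0.23 log units; within the scatter), in which 3-chlorophenyl replaced 2-methylphenyl and little moved. A similar outcome is expected here, with a step of a 1.7-fold higher number from compound 1 to compound 3 (0.22 log units; within the scatter) that stays within the scatter. Compound 3 is therefore estimated at 50 nM in this assay, between 15 nM and 160 nM.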

Compound 3, inhibition constant: 283 nM
For compound 3 the middle estimate is 5.7-fold (0.75 log units) below the measured one; the whole stated range lies below it.
By their numbers in this assay, from the lowest: compounds 1 and 2 (each within the scatter of the next); then compound 3.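

In this assay, the group on this amine nitrogen in a ring proves less freely exchangeable than compound 2 had suggested: the full change gives a 9.5-fold higher number from compound 1 to compound 3 (0.98 log units; beyond the scatter) and trifluoromethyl in place of chloro on an aromatic carbon alone gives a 5.6-fold higher number from compound 2 to compound 3 (0.75 log units; beyond the scatter). Among these compounds the rise therefore goes with trifluoromethyl, since 3-chlorophenyl in compound 2 stayed within the scatter of compound 1. Nothing available explains this difference. Left open is how a methoxy or nitrile group in place of trifluoromethyl would read, and whether the same swap gives a similar step with a longer chain.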